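The compounds below may be only part of what the source reports. "The series", "measured", "known", "first", "only" and "open" are said of these compounds alone.

Compound 1 `C[C@H](NC(=O)[C@@H]1CCCN1C)c1ccc(NC(=O)N2CC(c3cccnc3)C2)cc1`: > 1000000 nM
Compound 2 `C[C@H](NC(=O)C1CCOCC1)c1ccc(NC(=O)N2CC(c3ccc(N)nc3)C2)cc1`: 310000 nM

Both results come from a physicochemical assay for solubility, read by LC-MS, in phosphate buffer, with a stated time of 24 h, at pH 6.8; on this read-out lower numbers stand for lower solubility and higher numbers for higher solubility. Among the compounds with values here, compound 2 holds the only actual number of the pair, at 310000 nM. The entry for compound 1, > 1000000 nM, is a limit of the assay and not a number.

Compound 3 `C[C@H](NC(=O)[C@@H]1CCCN1C)c1ccc(NC(=O)N2CC(c3ccc(N)nc3)C2)cc1` has not yet been measured. It keeps the frame of compound 2 but places 1-methylpyrrolidin-2-yl in place of oxan-4-yl on a carbonyl carbon. Within the data shown here, compound 1 carries that same 1-methylpyrrolidin-2-yl group and reads > 1000000 nM, so an upward move beyond the usual scatter is expected, though no measured step tests this change directly. The estimated size of the move is a 2.3-fold higher number from compound 2 to compound 3 (0.35 log units; beyond the scatter). For compound 3 the expected value is 700000 nM, with an estimated range of 300000 nM to 1000000 nM.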

Compound 3, solubility: 760000 nM
Compound 3: the middle estimate sits 1.1-fold (0.04 log units) below what was measured; the range from low to high includes it.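

In this assay, within the data shown here, 1-methylpyrrolidin-2-yl in place of oxan-4-yl on a carbonyl carbon gives a 2.5-fold higher number from compound 2 to compound 3 (0.39 log units; beyond the scatter), the first direct reading of this change, between two groups that match in their counts of heavy atoms and hydrogen-bond acceptors. Amino in place of hydrogen on an aromatic carbon can now also be read, as an at least 1.3-fold lower number from compound 1 to compound 3 (0.11 log units; that floor lies within the scatter). The true size of that second step stays unknown because compound 1 has a limit of the assay and not a number: the limit of > 1000000 nM in this assay, at which 1 of the 3 values shown sits.

Going by these compounds, whether a carboxylic acid or an open-chain amine such as dimethylaminomethyl on the same carbonyl carbon would read higher or lower than 1-methylpyrrolidin-2-yl remains open. The mirror-image form of 1-methylpyrrolidin-2-yl is also left open.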